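A few compounds are considered here, and "the series" means these few. Any claim that something is new, unique, unknown or untested is made for them only; others in the source may bear on it.

Measured compounds:
Compound 1 `CCN(C(=O)C1CCN(S(=O)(=O)c2ccc3cn[nH]c3c2)CC1)[C@H](C)c1ccccc1` gives 87% in a functional assay on CHO cells for positive allosteric modulation of muscarinic acetylcholine receptor M5 (Homo sapiens), read by calcium flux; a higher number here means a larger maximal response, a lower number a smaller maximal response.
Compound 2 `CCN(Cc1cccc(C)c1)C(=O)C1CCN(S(=O)(=O)c2ccc3cn[nH]c3c2)CC1` gives 78% in this assay.

Compound 2 carries the lower of the two numbers, but the gap to compound 1, a number 9 percentage points lower from compound 1 to compound 2 (within the scatter), lies within the scatter, so the two compounds cannot be told apart on this read-out.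

Compound 3 `CCN(Cc1ccccc1OC)C(=O)C1CCN(S(=O)(=O)c2ccc3cn[nH]c3c2)CC1` differs from compound 2 in one place: 2-methoxyphenyl in place of 3-methylphenyl on a saturated chain carbon bound to an amide-type nitrogen. The change is confined to the ring that hangs on the amide-type nitrogen; the core and the rest of the molecule stay as in compound 2.

Going by the values given here, only one measured step bears on this part of the structure, and it is the step of a number 9 percentage points lower from compound 1 to compound 2 (within the scatter), which swapped the whole group on the amide-type nitrogen and left the maximal response within the scatter. Among the compounds with values here, no measured pair changes the substituent on that ring alone, so a direct guide for a methoxy group in place of a methyl group does not exist. Within the data shown here, with the one related step being small, a step no larger than the scatter is expected for compound 3, a number 2 percentage points higher from compound 2 to compound 3 (within the scatter). Compound 3 is therefore estimated at 80%, with a range from 64% to 96%.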

Compound 3, largest response reached (reported as percent of maximum), in percent of the reference or control that the assay uses: 92%
Compound 3: the middle estimate sits 12 percentage points below what was measured; the measured number falls inside the stated range.
By their numbers in this assay, from the lowest: compounds 2, 1 and 3 (each within the scatter of the next, the first and the last beyond it).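

Changing only the ring on the saturated chain carbon bound to an amide-type nitrogen is enough to shift the maximal response in this assay by more than the scatter (a number 14 percentage points higher from compound 2 to compound 3 (beyond the scatter)), so this position responds to a swap of 3-methylphenyl for 2-methoxyphenyl, in which an oxygen enters the group. Seen as a change of the whole group on the amide-type nitrogen, 2-methoxybenzyl cannot be told apart from 1-phenylethyl (a number 5 percentage points higher from compound 1 to compound 3 (within the scatter)), so the step from compound 2 marks a difference between two ring substituents, and no compound here stands clear of all the others. No measurement shown offers an explanation for this step.

Two things change at once in this swap, the substituent and its place on the ring, and a 3-methoxyphenyl or 2-methylphenyl group would be needed to separate them. Also open, going by these compounds, is how this assay would respond to an amine or a carboxylic acid on this ring, or to a longer chain in place of the ethyl group on the same nitrogen.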